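A Sulfonamide Exchange at the Weaker End of the Series

A few compounds are considered here, and "the series" means these few. Any claim that something is new, unique, unknown or untested is made for them only; others in the source may bear on it.

Going by the values given here, compound 2 `NS(=O)(=O)c1cccc(-c2nc(C(c3ccc(F)cc3)c3ccc(F)cc3)sc2CC(=O)O)c1` stands at the higher of the two numbers measured so far. In an in vitro assay on HEK385-7 cells for displacement of a labelled ligand from prostaglandin D2 receptor 2 (Homo sapiens) (on this read-out lower numbers stand for stronger inhibition and higher numbers for weaker inhibition), compound 2 gives 140 nM, whereas compound 1 `O=C(O)Cc1sc(C(c2ccc(F)cc2)c2ccc(F)cc2)nc1-c1ccc(Cl)cc1` gives 9.7 nM in this assay. Among the compounds with values here, the only measured step, a 14-fold higher number from compound 1 to compound 2 (1.16 log units; beyond the scatter), concerns 3-sulfamoylphenyl in place of 4-chlorophenyl and thus describes a different exchange from the one now considered. Compound 3 `CS(=O)(=O)Nc1cccc(-c2nc(C(c3ccc(F)cc3)c3ccc(F)cc3)sc2CC(=O)O)c1` differs from compound 2 by methanesulfonamido in place of sulfamoyl on an aromatic carbon. Within the data shown here, no measured step covers this change, and the one step known bears on it only as a reminder that changes at this aromatic carbon can be large. With nothing more to go on, a step in this assay no larger than the usual scatter is expected, in no preferred direction. Compound 3 is therefore expected to give about 120 nM in this assay, with a likely range from 40 nM to 400 nM. This estimate means an expected step of a 1.2-fold lower number from compound 2 to compound 3 (0.07 log units; within the scatter).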

Compound 3, half-maximal inhibitory concentration: 40 nM
The estimate for compound 3 lay 3.0-fold (0.48 log units) above the measured number; low and high end bracket the measured number.
By their numbers in this assay, from the lowest: compound 1; then compound 3; then compound 2.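

In this assay, the exchange of sulfamoyl for methanesulfonamido on this aromatic carbon gives a 3.5-fold lower number from compound 2 to compound 3 (0.54 log units; beyond the scatter), so two groups with the same counts of hydrogen-bond donors and acceptors are not interchangeable at this position. The gain is partial, since replacing the 4-chlorophenyl group with 3-(methanesulfonamido)phenyl still gives a 4.1-fold higher number from compound 1 to compound 3 (0.62 log units; beyond the scatter), a smaller step than a 14-fold higher number from compound 1 to compound 2 (1.16 log units; beyond the scatter). No available evidence accounts for the difference between the two sulfur-containing groups.

Going by these compounds, whether an ethanesulfonamido group, with a longer chain on the sulfonyl, would extend the gain remains open. On these data alone, it is also open whether an acetamido group, which has a carbonyl in place of the sulfonyl, or a simple amine would fall nearer compound 3 or compound 2.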